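Oxan-4-yl for cyclohexyl on the sulfonamide nitrogen

The source may report more compounds than this note shows. Statements on the series, on what has been measured and on what is new or still open speak of the compounds shown alone.

Of the compounds shown here, two sharing one core have been measured so far. For the measured compounds named here, in a physicochemical assay for solubility, in phosphate buffer, measured as kinetic solubility, at pH 7.4, tested at 250 uM (a lower number here means a less soluble compound, a higher number a more soluble compound), compound 1 (`O=C(O)c1ccc(NCCCCCCCC(F)(F)F)c(S(=O)(=O)N2CCCCC2)c1`) gives 13000 nM and compound 2 (`O=C(O)c1ccc(NCCCCCCCC(F)(F)F)c(S(=O)(=O)NC2CCCCC2)c1`) gives 9000 nM on the same scale, so compound 2 stands within the scatter of the only other measured compound.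

Compound 3 (`O=C(O)c1ccc(NCCCCCCCC(F)(F)F)c(S(=O)(=O)NC2CCOCC2)c1`) carries oxan-4-yl in place of cyclohexyl on a sulfonamide nitrogen, and oxan-4-yl in place of cyclohexyl on a sulfonamide nitrogen is the whole difference from compound 2.

Going by the values given here, one measured step bears on this, and only indirectly. It is a 1.4-fold lower number from compound 1 to compound 2 (0.16 log units; within the scatter) for cyclohexylamino in place of piperidin-1-yl on a sulfonyl sulfur, a change at the same part of the molecule that stays within the scatter. Among the compounds with values here, no measured step exchanges cyclohexyl for oxan-4-yl, so the direction is a judgement from the structural change alone. The expected outcome is a modest move toward a higher number, read as a 1.8-fold higher number from compound 2 to compound 3 (0.25 log units; within the scatter) in this assay and starting from compound 2 at 9000 nM as the anchor. Compound 3 is estimated at 16000 nM with an expected range of 7000 nM to 40000 nM as a working figure.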

Compound 3, solubility: 244000 nM
Beside the measured number, compound 3's estimate is 15-fold (1.18 log units) below it, and the stated range ends below it.
By their numbers in this assay, from the lowest: compounds 2 and 1 (each within the scatter of the next); then compound 3.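

On the sulfonamide nitrogen, the ring atom exchanged in oxan-4-yl for cyclohexyl marks a sharp break in this assay: the read-out shows a 27-fold higher number from compound 2 to compound 3 (1.43 log units; beyond the scatter) for a change that keeps the ring size and adds one hydrogen-bond acceptor. The earlier compounds shown here gave no sign of this range, since a 1.4-fold lower number from compound 1 to compound 2 (0.16 log units; within the scatter) for cyclohexylamino in place of piperidin-1-yl on a sulfonyl sulfur, whereas the oxygen-containing ring gives a 19-fold higher number from compound 1 to compound 3 (1.27 log units; beyond the scatter) for (oxan-4-yl)amino in place of the same piperidin-1-yl group. No supporting evidence is available to account for the size of this step.

The compounds shown leave open whether the large step belongs to the ring oxygen specifically or would also appear with another ring on the sulfonamide nitrogen, such as piperidin-4-yl or oxetan-3-yl, or with an open-chain ether such as 2-methoxyethyl. They also leave open whether the same exchange holds its size with a shorter chain on the amine of the shared core, or with an amide in place of the carboxylic acid.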